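Cyclopentyl Ether Gives Way to an Imidazolylpropyl Chain

The source may hold more compounds than are shown below. What is called first, only, known or untested is meant among the compounds shown, and "the series" means these compounds.

Compound 3 `Cn1c(=O)c2[nH]c(-c3ccc(OC4CCCC4)cc3)nc2n(C)c1=O` holds the lowest of the two numbers recorded in an assay on CHO cells for binding affinity to adenosine receptor A2b (Homo sapiens), with a stated time of 20 min (on this read-out lower numbers stand for stronger inhibition and higher numbers for weaker inhibition), where compound 3 gives 1 nM. Compound 2 `Cn1c(=O)c2[nH]c(-c3ccc(OCCC4CCNCC4)cc3)nc2n(C)c1=O` gives 2.9 nM. Compound 1 `Cn1c(=O)c2[nH]c(-c3ccc(OCCCCl)cc3)nc2n(C)c1=O` gives only a limit of the assay, > 10 nM. The change to compound 4 `Cn1c(=O)c2[nH]c(-c3ccc(OCCCn4ccnc4)cc3)nc2n(C)c1=O` is 3-(1H-imidazol-1-yl)propyl in place of cyclopentyl on an oxygen on an aromatic ring. For the measured compounds named here, two measured steps bear on it, both running toward the cyclopentyl ether: an at least 10-fold lower number from compound 1 to compound 3 (1.00 log units; beyond the scatter) and a 2.9-fold lower number from compound 2 to compound 3 (0.46 log units; beyond the scatter). In both cases the cyclopentyl group on the aromatic oxygen gave the lower number than an open chain, and compound 4 goes the other way, back to an open chain carrying a ring at its end. A higher number is therefore expected for compound 4, with the step estimated at about a 5.0-fold higher number from compound 3 to compound 4 (0.70 log units; beyond the scatter). That rise is expected to be modest rather than large, as a 2.9-fold lower number from compound 2 to compound 3 (0.46 log units; beyond the scatter) was itself only modest. In this assay compound 4 is estimated at 5 nM, with a range from 1.5 nM to 20 nM.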

Compound 4, inhibition constant: 1.05 nM
The estimate for compound 4 lay 4.8-fold (0.68 log units) above the measured number, outside the stated range (below it).
By their numbers in this assay, from the lowest: compounds 3 and 4 (each within the scatter of the next); then compound 2. At a limit, above all of these: compound 1.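

With a 1.1-fold higher number from compound 3 to compound 4 (0.02 log units; within the scatter), this oxygen on an aromatic ring carries 3-(1H-imidazol-1-yl)propyl and cyclopentyl without a difference beyond the scatter, so an open chain here need not give the higher number that compound 1 and compound 2 had suggested. The group at the end of the chain therefore counts, as seen in a 2.8-fold lower number from compound 2 to compound 4 (0.44 log units; beyond the scatter) and in an at least 9.5-fold lower number from compound 1 to compound 4 (0.97 log units; beyond the scatter). The value of compound 1 is a limit and not a number: the limit of > 10 nM in this assay, at which 1 of the 4 values shown sits.

The compounds shown leave open whether the result depends on the 1H-imidazol-1-yl ring itself or on the chain that holds it. A longer or shorter chain to the same ring, or a phenyl ring, a dimethylamine or a carboxylic acid at the end of the propyl chain, would help to separate these.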